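The compounds below may be only part of what the source reports. "The series", "measured", "known", "first", "only" and "open" are said of these compounds alone.

Compound 1 `O=C(/C=C/c1coc2cc(O)ccc2c1=O)NCc1ccccc1`: 436000 nM
Compound 2 `O=C(/C=C/c1coc2cc(O)ccc2c1=O)NCc1ccc(F)cc1`: 357000 nM
Compound 3 `COc1ccc(NC(=O)/C=C/c2coc3cc(O)ccc3c2=O)cc1`: 976000 nM

In an ADME assay on HepG2 2.2.15 cells (Homo sapiens) for cytotoxicity, read by MTT assay, with stated times of 48 h and 9 days (a lower number here means that less compound is tolerated, a higher number that more compound is tolerated), compound 3 stands highest of the three numbers. The steps of a 2.2-fold higher number from compound 1 to compound 3 (0.35 log units; beyond the scatter) and a 2.7-fold higher number from compound 2 to compound 3 (0.44 log units; beyond the scatter) both lie beyond the scatter, while a 1.2-fold lower number from compound 1 to compound 2 (0.09 log units; within the scatter) stays within it. Compound 4 `Cc1ccccc1NC(=O)/C=C/c1coc2cc(O)ccc2c1=O` differs from compound 3 by 2-methylphenyl in place of 4-methoxyphenyl on an amide-type nitrogen. Among the measured compounds shown here, no measured step exchanges one aryl group for another on that nitrogen; the two steps that reach compound 3 swap a benzyl-type group for an aryl group and bear on this change only loosely. A step no larger than the scatter is therefore expected in this assay. Compound 4 is estimated at 750000 nM, with a range from 350000 nM to 1500000 nM. That estimate means an expected step of a 1.3-fold lower number from compound 3 to compound 4 (0.11 log units; within the scatter).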

Compound 4, half-maximal cytotoxic concentration: 374000 nM
Estimate against measurement, compound 4: 2.0-fold (0.30 log units) above; the measured number falls inside the stated range.
By their numbers in this assay, from the lowest: compounds 2, 4 and 1 (each within the scatter of the next); then compound 3.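

In this assay, this exchange of one aryl group for another on the amide-type nitrogen gives a 2.6-fold lower number from compound 3 to compound 4 (0.42 log units; beyond the scatter), so an aryl group at that place does not by itself carry the higher number. The steps of a 1.0-fold higher number from compound 2 to compound 4 (0.02 log units; within the scatter) and a 1.2-fold lower number from compound 1 to compound 4 (0.07 log units; within the scatter) place the 2-methylphenyl compound level with the benzyl and 4-fluorobenzyl compounds, and the gain seen so far for the aryl swap belongs to 4-methoxyphenyl alone among the groups shown.

No measurement here explains these steps. Going by these compounds, how a phenyl ring carrying an amine or a carboxylic acid would behave on that nitrogen remains open.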